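From 2-methoxyphenyl to 3-fluorophenyl in a narrow series

The source may hold more compounds than are shown below. What is called first, only, known or untested is meant among the compounds shown, and "the series" means these compounds.

In a functional assay on HepG2 cells (Homo sapiens) for cytotoxicity, read by MTT assay, with a stated time of 72 h (on this read-out lower numbers stand for stronger inhibition and higher numbers for weaker inhibition), compound 1 (`COc1ccc(-c2cc(=O)c3c(O)cc(OCCCCN4CCN(C)CC4)c(OC)c3o2)cc1`) gives 4200 nM, compound 2 (`COc1c(OCCCCN2CCN(C)CC2)cc(O)c2c(=O)cc(-c3ccc(Cl)cc3)oc12`) gives 3750 nM and compound 3 (`COc1ccccc1-c1cc(=O)c2c(O)cc(OCCCCN3CCN(C)CC3)c(OC)c2o1`) gives 2330 nM, which places compound 3 within the scatter of both others. Compound 4 (`COc1c(OCCCCN2CCN(C)CC2)cc(O)c2c(=O)cc(-c3cccc(F)c3)oc12`) carries 3-fluorophenyl in place of 2-methoxyphenyl on an aromatic carbon, next to the ring oxygen: 3-fluorophenyl in place of 2-methoxyphenyl on an aromatic carbon. Among the compounds with values here, three measured steps bear on this change: a 1.1-fold lower number from compound 1 to compound 2 (0.05 log units; within the scatter), a 1.8-fold lower number from compound 1 to compound 3 (0.26 log units; within the scatter) and a 1.6-fold lower number from compound 2 to compound 3 (0.21 log units; within the scatter). Within the data shown here, none of them leaves the scatter, and no compound bearing fluorine has been measured yet, so no step beyond the scatter is expected in this assay. The expected step is a 1.3-fold higher number from compound 3 to compound 4 (0.11 log units; within the scatter). Compound 4 is estimated at 3000 nM, with an expected range of 1400 nM to 6500 nM.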

Compound 4, half-maximal inhibitory concentration: 2580 nM
Estimate against measurement, compound 4: 1.2-fold (0.07 log units) above, and the stated range covers the measured number.
By their numbers in this assay, from the lowest: compounds 3, 4, 2 and 1 (each within the scatter of the next).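

With 3-fluorophenyl at this place, next to the ring oxygen, this assay gives a 1.1-fold higher number from compound 3 to compound 4 (0.04 log units; within the scatter) and a 1.5-fold lower number from compound 2 to compound 4 (0.16 log units; within the scatter) and a 1.6-fold lower number from compound 1 to compound 4 (0.21 log units; within the scatter) in this narrow series. The first fluorine-bearing group therefore joins 2-methoxyphenyl, 4-chlorophenyl and 4-methoxyphenyl among groups that these four compounds do not separate on this read-out. No measured evidence bears on what lies behind this result. Still open, going by these compounds, is whether a phenyl group carrying an amine or a carboxylic acid at this same place would leave the scatter.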